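Replacing the benzyl phenyl with a cyclic sulfone

The source may report more compounds than this note shows. Statements on the series, on what has been measured and on what is new or still open speak of the compounds shown alone.

Measured compounds:
compound 1 `c1ccc(CN(CCCCN(C[C@H]2Cc3ccccc3CN2)[C@H]2CCCc3cccnc32)Cc2ccccc2)cc1`: > 16700 nM
compound 2 `c1ccc(CNCCCCN(C[C@H]2Cc3ccccc3CN2)[C@H]2CCCc3cccnc32)cc1`: 20.1 nM

In a functional assay on cells for antagonist activity at C-X-C chemokine receptor type 4 (Homo sapiens), read by fluorescence and calcium flux, with stated times of 25 min and 90 s (on this read-out lower numbers stand for stronger inhibition and higher numbers for weaker inhibition), compound 2 gives 20.1 nM. For compound 1 this assay reports only a limit, > 16700 nM, so its true value is not known. Going by the values given here, the one measured step, an at least 830-fold lower number from compound 1 to compound 2 (2.91 log units; beyond the scatter), concerns the amine nitrogen, not the ring, and the limit of > 16700 nM in this assay, at which 1 of the 2 values shown sits, means its full size is unknown. Compound 3 `O=S1(=O)CCC(CNCCCCN(C[C@H]2Cc3ccccc3CN2)[C@H]2CCCc3cccnc32)CC1` keeps the secondary amine of compound 2 and differs only in the ring: 1,1-dioxothian-4-yl in place of phenyl on a saturated chain carbon bound to an amine nitrogen. Among the compounds with values here, no measured step bears directly on this change; the only step shows that the secondary amine carries the activity, and compound 3 retains it. A moderate move, probably toward a higher number, is therefore expected in this assay, as a 3.0-fold higher number from compound 2 to compound 3 (0.47 log units; beyond the scatter), with compound 3 estimated at 60 nM within a range of 15 nM to 300 nM.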

Compound 3, half-maximal inhibitory concentration: 17 nM
Estimate against measurement, compound 3: 3.5-fold (0.55 log units) above; the range from low to high includes it.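

The change from phenyl to 1,1-dioxothian-4-yl, on a saturated chain carbon bound to an amine nitrogen, gives a 1.2-fold lower number from compound 2 to compound 3 (0.07 log units; within the scatter) in this assay, so the two compounds cannot be told apart on this read-out. The earlier step spoke only to the amine nitrogen, whereas this pair bears on the ring itself: at this place, a six-membered aromatic ring of carbon only is not needed for a value in this range, and a non-aromatic ring with 1 hetero atom and 2 hydrogen-bond acceptors serves as well. Nothing measured here accounts for this outcome.

The compounds shown do not say whether the sulfone matters, as a cyclohexyl, tetrahydropyran or piperidine ring at this place remains unread. From the compounds shown here alone, how a longer chain carrying 1,1-dioxothian-4-yl would read in this assay also stays open.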